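A few compounds are considered here, and "the series" means these few. Any claim that something is new, unique, unknown or untested is made for them only; others in the source may bear on it.

In a functional assay on HL-60 cells (Homo sapiens) for antiproliferative activity, read by MTT assay, with a stated time of 24 h (a higher number here means a weaker inhibitor, a lower number a stronger inhibitor), compound 3 `COc1cc(Nc2nccc(NCCCN)n2)cc(OC)c1OC` gives > 50000 nM, which is a limit of the assay and not a number. Compound 1 `CNC(=O)c1ccccc1Oc1nc(Nc2ccccc2F)ncc1Br` gives > 50000 nM, which is likewise a limit. For the measured compounds named here, compound 2 `CNC(=O)c1ccccc1Oc1nc(Nc2cccc(C(F)(F)F)c2)ncc1Br` gives 44000 nM, the only true number so far. The set therefore sits close to a ceiling: the limit of > 50000 nM in this assay, at which 2 of the 3 values shown sit.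

Compound 4 `COc1cc(Nc2ncc(I)c(NCCCN)n2)cc(OC)c1OC` is the next entry, and it departs from compound 3 by one change: iodo in place of hydrogen on an aromatic carbon. This puts iodo in place of hydrogen on an aromatic carbon, ortho to the (3-aminopropyl)amino group, while the chain and the rest of the structure stay the same.

Going by the values given here, no measured pair tests this change, so the expectation rests on the structural change alone and remains loose. The estimated step of an at least 6.2-fold lower number from compound 3 to compound 4 (0.79 log units; beyond the scatter) points toward a stronger inhibitor in this assay, though a reading that stays at the limit remains possible. For compound 4 the estimate is 8000 nM, with an expected range of 800 nM to 50000 nM.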

Compound 4, half-maximal inhibitory concentration: 43400 nM
Beside the measured number, compound 4's estimate is 5.4-fold (0.73 log units) below it; the range from low to high includes it.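

In this assay, iodo in place of hydrogen, ortho to the (3-aminopropyl)amino group, gives an at least 1.1-fold lower number from compound 3 to compound 4 (0.06 log units; that floor lies within the scatter). For the compounds shown here, this is the first step readable, and its floor lies within the scatter, so the data show no firm gain from iodo at this position. Compound 4, at 43400 nM, does yield a true number. Compound 3 stands at a limit of the assay, > 50000 nM, which is not a number, so the full size of the step cannot be read: the limit of > 50000 nM in this assay, at which 2 of the 4 values shown sit.

From the compounds shown here alone, whether a chloro or methyl group at this position would give a number clear of that ceiling remains open. Also open, going by these compounds, is whether a longer chain in place of the (3-aminopropyl)amino group would change the reading with iodo kept in place.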